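A few compounds are considered here, and "the series" means these few. Any claim that something is new, unique, unknown or untested is made for them only; others in the source may bear on it.

Series notes. Compound 1 `C=CC(=O)Nc1cccc(NC(=O)CSc2nc(Nc3ccccc3Cl)c3ccccc3n2)c1`, compound 2 `C=CC(=O)Nc1cccc(NC(=O)CSc2nc(Nc3ccccc3Br)c3ccccc3n2)c1` and compound 3 `C=CC(=O)Nc1cccc(NC(=O)CSc2nc(Nc3ccc(Cl)cc3)c3ccccc3n2)c1` share one core and differ only in the halogenated phenyl carried on the ring nitrogen; compound 4 `C=CC(=O)Nc1cccc(NC(=O)CSc2nc(Nc3ccc(Br)cc3)c3ccccc3n2)c1` belongs to the same set and has not yet been measured. In a functional assay on NCI-H1975 cells (Homo sapiens) for inhibition, read by MTT assay, with a stated time of 72 h (a higher number here means a weaker inhibitor, a lower number a stronger inhibitor), compound 1 gives 10000 nM. In this assay compound 2 gives 19300 nM, and compound 3 gives 7580 nM. The cores of compound 1 and compound 3 differ as 4-chlorophenyl in place of 2-chlorophenyl on a nitrogen on an aromatic ring, and the step is a 1.3-fold lower number from compound 1 to compound 3 (0.12 log units; within the scatter). Between compound 2 and compound 3 the step is a 2.5-fold lower number from compound 2 to compound 3 (0.41 log units; beyond the scatter). The halogen exchange bromo in place of chloro on an aromatic carbon gave a 1.9-fold higher number from compound 1 to compound 2 (0.29 log units; within the scatter). Going from compound 3 to compound 4 is the same kind of change, (bromo in place of chloro on an aromatic carbon), but the two places are not the same word for word: in the first the group sits "ortho to a large group", in the second "para to a large group", so it is the same kind of change and not the same change. This exchange occurs twice among the compounds shown, once measured and once not. For compound 4 the expected step is a 1.5-fold higher number from compound 3 to compound 4 (0.16 log units; within the scatter), resting on compound 1 and compound 2 with a 1.9-fold higher number from compound 1 to compound 2 (0.29 log units; within the scatter), with wider room allowed since the place around the change differs. Compound 4 is therefore estimated at 11000 nM in this assay, expected to fall between 6000 nM and 22000 nM.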

Compound 4, half-maximal inhibitory concentration: 6280 nM
For compound 4 the middle estimate is 1.8-fold (0.24 log units) above the measured one, and the stated range covers the measured number.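

In this assay the exchange of chloro for bromo on the aromatic carbon reads a 1.2-fold lower number from compound 3 to compound 4 (0.08 log units; within the scatter), and set beside the same exchange on the other core, the two steps show no difference that stands clear of the usual scatter: the same change on two cores in this assay, a 1.9-fold higher number (0.29 log units; within the scatter) from compound 1 to compound 2 and a 1.2-fold lower number (0.08 log units; within the scatter) from compound 3 to compound 4, 2.3-fold (0.37 log units) apart, within the scatter of two such steps

Within the data shown here, this gives no sign that the exchange behaves differently on the two cores, but both steps are small and only two pairs are at hand, so it does not show that the exchange carries over in general. Of the steps that change the halogenated phenyl, only a 3.1-fold lower number from compound 2 to compound 4 (0.49 log units; beyond the scatter) lies beyond the scatter and it is modest, whereas a 1.6-fold lower number from compound 1 to compound 4 (0.20 log units; within the scatter) and a 1.3-fold lower number from compound 1 to compound 3 (0.12 log units; within the scatter) stay within it, so these two go against any general gain from 4-halophenyl over 2-halophenyl.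

Open, from the compounds shown here alone, is how a 4-fluorophenyl, 4-methoxyphenyl or 4-aminophenyl group on the same nitrogen would read in this assay. Also open, going by these compounds, is whether the bromo and chloro pairs would still read alike with a longer chain in place of the linking chain of the shared core.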